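A New Nitrophenyl Group on a Fast-Disappearing Compound

The compounds below may be only part of what the source reports. "The series", "measured", "known", "first", "only" and "open" are said of these compounds alone.

Within the data shown here, in an ADME assay on microsomes from liver (Homo sapiens) for metabolic stability, read by LC-MS, using NADPH, with a stated time of 60 min, tested at 1 uM (a lower number here means that the compound disappears faster, a higher number that the compound lasts longer), compound 1 `CN(C)c1ccc(C2CCCN2Cc2ccc(-c3ccccc3[N+](=O)[O-])o2)cc1` gives 0.0423 h, the higher of the two numbers measured so far. Among the measured compounds shown here, the only other measured compound, compound 2 `COc1ccc(C2CCCN2Cc2ccc(-c3ccccc3[N+](=O)[O-])o2)cc1`, gives 0.0183 h. Its difference is methoxy in place of dimethylamino on an aromatic carbon, and the step is a 2.3-fold lower number from compound 1 to compound 2 (0.36 log units; beyond the scatter).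

Compound 3 `Cc1cc([N+](=O)[O-])ccc1-c1ccc(CN2CCCC2c2ccc(N(C)C)cc2)o1` keeps the dimethylamino group and the core of compound 1 but changes another part of the molecule: 2-methyl-4-nitrophenyl in place of 2-nitrophenyl on an aromatic carbon. Put simply, 2-methyl-4-nitrophenyl stands in place of 2-nitrophenyl, on an aromatic carbon of a five-membered aromatic ring with 1 oxygen.

For the measured compounds named here, no measured step involves this group. The modest step to compound 2 shows only how far one change elsewhere moved the number, and it gives no direction for this new change. With no evidence favouring a rise or a fall, no shift beyond the scatter is expected in this assay. The expected step is a 1.1-fold lower number from compound 1 to compound 3 (0.02 log units; within the scatter). Compound 3 is expected to give about 0.04 h, with an estimated range of 0.017 h to 0.095 h.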

Compound 3, half-life: 0.228 h
Estimate against measurement, compound 3: 5.7-fold (0.76 log units) below, and the stated range ends below it.
By their numbers in this assay, from the lowest: compound 2; then compound 1; then compound 3.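

The aryl group next to the ring oxygen turns out to matter in this assay, with a 5.4-fold higher number from compound 1 to compound 3 (0.73 log units; beyond the scatter), so the number responds to changes at this end of the molecule as well as at the dimethylamino end. Swapping 2-nitrophenyl for 2-methyl-4-nitrophenyl keeps the aromatic ring and the counts of hydrogen-bond donors and acceptors the same, yet the change combines two edits: a methyl group is added and the nitro group sits elsewhere on the ring. Nothing shown explains why the number rises, and no supporting measurement bears on the cause.

The compounds shown leave open whether the methyl group, the new place of the nitro group or the two together account for the step, a question that a phenyl ring carrying only one of these groups could help to settle. On these data alone, it also remains open whether the higher number would hold with a nitrile or a carboxylic acid in place of the nitro group, or with methoxy in place of dimethylamino, as in compound 2.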